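The source may report more compounds than this note shows. Statements on the series, on what has been measured and on what is new or still open speak of the compounds shown alone.

Compound 2 `Cc1cc2c(cn1)c(N)nn2C` gives -2% in an assay on isolated protein for inhibition of RAC-beta serine/threonine-protein kinase (Homo sapiens), read by mobility shift assay, tested at 30 uM; a higher number here means more inhibition at the concentration tested (going by the name of the read-out), a lower number less inhibition; compound 1 `Cc1cc2c(c(N)nn2C)c(N2CCCCC2)n1` gives 0%, and the step of a number 2 percentage points lower from compound 1 to compound 2 (within the scatter) leaves the two numbers within the scatter of each other, so neither shows any inhibition. Compound 3 `Cc1cc2[nH]nc(N)c2cn1` differs from compound 2 by hydrogen in place of methyl on an aromatic nitrogen. For the measured compounds named here, no measured step touches this nitrogen, so nothing here shows how much this change can move the read-out, and the one step measured changed almost nothing. Compound 3 is therefore expected to give about 0%, between -12% and 12%, a step of a number 2 percentage points higher from compound 2 to compound 3 (within the scatter) that is expected to stay within the scatter.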

Compound 3, a percentage reported as inhibition, at one concentration (the size of the read-out at that concentration, not a potency): -3%
The estimate for compound 3 lay 3 percentage points above the measured number; the measured number falls inside the stated range.
By their numbers in this assay, from the lowest: compounds 3, 2 and 1 (each within the scatter of the next).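

In this assay, hydrogen in place of methyl on an aromatic nitrogen gives a number 1 percentage points lower from compound 2 to compound 3 (within the scatter) and so adds a measured step at this nitrogen. Neither compound shows inhibition, so losing this methyl does not bring any out, but a change in a compound without inhibition cannot show whether the methyl matters in one that has it. No measurement available here offers an explanation for this result.

From the compounds shown here alone, it remains open whether an ethyl group or a longer chain ending in an amine on this nitrogen would give any inhibition. The same question stands for a carboxylic acid in place of the amino group.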